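Extending the chain on the core of compound 2

The source may hold more compounds than are shown below. What is called first, only, known or untested is meant among the compounds shown, and "the series" means these compounds.

Compound 2, with structure `COc1ccc(Nc2cc(C)oc(=O)c2)cc1`, carries a methyl on its core. In a functional assay on KBVIN cells (Homo sapiens) for cytotoxicity, read by MTT assay, with a stated time of 72 h (on this read-out lower numbers stand for an effect already at smaller amounts and higher numbers for an effect only at larger amounts of compound), compound 2 gives > 30 uM, which is a limit of the assay rather than a number. This is the limit of > 30 uM in this assay, at which 1 of the 3 values shown sits. Compound 4, with structure `CCCCCc1cc(Nc2ccc(OC)cc2)cc(=O)o1`, differs from compound 2 by butyl in place of hydrogen on a saturated chain carbon bound to an aromatic carbon.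

Within the data shown here, no measured step changes this chain. Among the measured compounds shown here, the only measured step concerns the aryl amine: compound 1, `COc1cccc(Nc2cc(-c3ccccc3)oc(=O)c2)c1`, gives 0.55 uM in this assay, and compound 3, `O=c1cc(Nc2ccccc2)cc(-c2ccccc2)o1`, gives 0.15 uM, with a 3.7-fold lower number from compound 1 to compound 3 (0.56 log units; beyond the scatter). Compounds 1 and 3, which carry a phenyl where compound 2 carries a methyl, both give numbers, while compound 2 reaches only a limit; these pairs differ in more than one place, so they show only that the two classes of value differ. Whether a pentyl chain behaves more like phenyl or like methyl is not shown.

On that basis compound 4 is estimated to give 10 uM in this assay, in a range from 2 uM to 30 uM, which would mean an expected step of an at least 3.0-fold lower number from compound 2 to compound 4 (0.47 log units; beyond the scatter), with a fair chance that compound 4 again reaches only a limit.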

Compound 4, concentration for half-maximal effect: 4.84 uM
The estimate for compound 4 lay 2.1-fold (0.32 log units) above the measured number, within the range that was stated.
By their numbers in this assay, from the lowest: compound 3; then compound 1; then compound 4. At a limit, above all of these: compound 2.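

In this assay, among these compounds, butyl in place of hydrogen on a saturated chain carbon bound to an aromatic carbon gives an at least 6.1-fold lower number from compound 2 to compound 4 (0.79 log units; beyond the scatter), the first step that can be read at this position. The earlier compounds shown here offered no pair that changed this position alone, whereas here the rest of the structure stays the same, so a saturated chain with no ring is enough to bring a number out of this assay. The size of the step stays open on one side, because compound 2 gives a limit of the assay and not a number: the limit of > 30 uM in this assay, at which 1 of the 4 values shown sits.

The compounds shown give only methyl and pentyl on this carbon, so how the number follows chain length is open, and neither a propyl, a longer chain such as heptyl, nor a chain ending in an amine or a carboxylic acid can be placed. As far as these compounds go, whether pentyl and phenyl rank in any order at this position also stays open, and so does whether the step seen on removing the methoxy group would carry over to the pentyl series.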